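The compounds below may be only part of what the source reports. "The series", "measured", "known", "first", "only" and "open" are said of these compounds alone.

Measured so far:
- compound 1, `COc1ccc(-c2cc(-c3ccc(OC)cc3)on2)cc1`, > 100000 nM
- compound 2, `COc1ccc(-c2noc(-c3ccc(OC)cc3)c2C)cc1`, > 100000 nM
- compound 3, `Oc1ccc(-c2cc(-c3ccc(O)cc3)on2)cc1`, 6300 nM

Of the compounds shown here, three built on one shared core have been tested in an ADME assay on HMEC-1 cells (Homo sapiens) for antiproliferative activity, read by cell counting, with a stated time of 5 days; a lower number here means a stronger inhibitor, a higher number a weaker inhibitor. Compound 1 carries two methoxy groups, and in this assay compound 1 gives only a limit of the assay, > 100000 nM, not a number. Compound 2 likewise returns a limit, > 100000 nM. The step that the two limits leave unreadable from compound 1 to compound 2 is therefore (methyl in place of hydrogen on an aromatic carbon), and its size cannot be read, since both values sit at the limit of > 100000 nM in this assay, at which 2 of the 3 values shown sit. Compound 3, with two hydroxyl groups instead, gives a measurable number, 6300 nM; how its core differs from that of compound 1 is not broken down here.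

The compound still to be measured is compound 4, `Cc1c(-c2ccc(O)cc2)noc1-c1ccc(O)cc1`. It differs from compound 3 by methyl in place of hydrogen on an aromatic carbon, while in the pair of compound 1 and compound 2 the same kind of change sits next to two ring atoms that each bear a group of 8 heavy atoms rather than 7. Going by the values given here, the only measured example of this change is unreadable, so the expectation rests on compound 3 alone, whose value 6300 nM is the starting point, and on the assumption that a single methyl moves the number only modestly. The step of a 1.6-fold higher number from compound 3 to compound 4 (0.20 log units; within the scatter) is the estimated change. Compound 4 is expected to give about 10000 nM, somewhere between 3000 nM and 40000 nM.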

Compound 4, half-maximal inhibitory concentration: 47000 nM
Estimate against measurement, compound 4: 4.7-fold (0.67 log units) below; measured number above the stated range.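

In this assay, putting methyl in place of hydrogen on the aromatic carbon of the five-membered ring gives a 7.5-fold higher number from compound 3 to compound 4 (0.87 log units; beyond the scatter), so on the core that carries two hydroxyl groups, this small change makes the compound a clearly weaker inhibitor. As far as these compounds go, the same change on the core that carries two methoxy groups cannot be read, since compound 1 and compound 2 give no numbers to compare: the limit of > 100000 nM in this assay, at which 2 of the 4 values shown sit. This leaves a single readable example of the change, which shows what methyl does on the hydroxyl-bearing core but not whether the effect carries over to the methoxy-bearing core, where its size and even its direction remain unknown.

The compounds shown leave open how other groups on that same aromatic carbon would compare with hydrogen and methyl, for example an amine, a carboxylic acid or a longer chain such as ethyl. They also leave open why methyl raises the number on the hydroxyl-bearing core, and whether a core carrying one hydroxyl group and one methoxy group would respond to methyl in the same way.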